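The source may hold more compounds than are shown below. What is called first, only, known or untested is meant among the compounds shown, and "the series" means these compounds.

Compound 1, `Oc1ccccc1-c1cc(-c2ccc(OC(F)(F)F)cc2)cc(-c2ccccc2O)n1`, in a functional assay on HeLa cells (Homo sapiens) for inhibition (on this read-out higher numbers stand for weaker inhibition and lower numbers for stronger inhibition), gives only a limit, > 50000 nM.
Compound 2, `Oc1cccc(-c2cc(-c3ccc(OC(F)(F)F)cc3)cc(-c3ccccc3O)n2)c1`, in this assay gives 20600 nM.

Among the compounds with values here, compound 2 thus holds the only actual number here; the value of compound 1 is a limit, as is recorded in the limit of > 50000 nM in this assay, at which 1 of the 2 values shown sits. Within the data shown here, the one measured step, an at least 2.4-fold lower number from compound 1 to compound 2 (0.38 log units; beyond the scatter), moves the hydroxyl on one of the two outer phenyl groups of the shared core and brings the number down from the limit into the measurable range.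

Compound 3, `Oc1ccc(-c2cc(-c3ccc(OC(F)(F)F)cc3)cc(-c3ccccc3O)n2)cc1`, carries the same atoms joined differently: 4-hydroxyphenyl in place of 3-hydroxyphenyl on an aromatic carbon. Among the measured compounds shown here, this is a second shift of the same hydroxyl on the same outer ring, so the step from compound 1 to compound 2 is the only guide, and it speaks for a change of at most modest size in either direction. Because the starting number is compound 2 with 20600 nM, compound 3 is expected to land close to it, with a 1.4-fold lower number from compound 2 to compound 3 (0.14 log units; within the scatter) as the estimated step. The estimate for compound 3 in this assay is 15000 nM, expected between 5000 nM and 50000 nM.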

Compound 3, half-maximal inhibitory concentration: > 50000 nM
Compound 3 gave a limit, no number (the forecaster's own chance of this, stated with the estimate: 20%); middle value at least 3.3-fold (0.52 log units) from the limit.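

In this assay, the change to 4-hydroxyphenyl gives an at least 2.4-fold higher number from compound 2 to compound 3 (0.38 log units; beyond the scatter), so the gain seen on going to 3-hydroxyphenyl does not continue as the hydroxyl moves along this outer ring. Among these three compounds, only compound 2, with 3-hydroxyphenyl, gives a number rather than a limit, so the read-out depends on where the hydroxyl sits but does not change steadily in one direction, and compound 3 goes against any trend suggested by the first step alone. Compound 1 and compound 3 stop at the same limit, so the step between them cannot be read: the limit of > 50000 nM in this assay, at which 2 of the 3 values shown sit.

As far as these compounds go, it remains open how far the true values of compound 1 and compound 3 lie beyond that limit, and whether the same shift of the hydroxyl on the other outer ring, which stays 2-hydroxyphenyl throughout, would have a similar effect. From the compounds shown here alone, it is also open whether an amine, a methoxy group or a carboxylic acid in place of the hydroxyl on this ring would give a number higher or lower than that of compound 2.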